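Swapping an amine for a methoxyethoxy ether on the acyl chain

The source may report more compounds than this note shows. Statements on the series, on what has been measured and on what is new or still open speak of the compounds shown alone.

Compound 2, with structure `NCC(=O)NS(=O)(=O)c1ccc(Nc2nc(N)n(C(=O)c3c(F)cccc3F)n2)cc1`, is one of two measured compounds in a physicochemical assay for solubility, at pH 7.4; on this read-out lower numbers stand for lower solubility and higher numbers for higher solubility. In this assay, among the measured compounds shown here, compound 2 gives 200 ug/mL, the only plain number recorded. Compound 1, with structure `Nc1nc(Nc2ccc(S(=O)(=O)NC(=O)CCC(=O)O)cc2)nn1C(=O)c1c(F)cccc1F`, returns > 1000 ug/mL, which is a limit of the assay rather than a number. For the measured compounds named here, the one measured step, an at least 5.0-fold lower number from compound 1 to compound 2 (0.69 log units; beyond the scatter), is therefore the only guide available. Compound 3, with structure `COCCOCC(=O)NS(=O)(=O)c1ccc(Nc2nc(N)n(C(=O)c3c(F)cccc3F)n2)cc1`, differs from compound 2 in one place: 2-methoxyethoxy in place of amino on a saturated chain carbon bound to a carbonyl carbon. This change is not the same as the measured step, which exchanged a carboxymethyl for an amino group; here the amino group leaves and a neutral ether chain enters, so the measured step cannot be carried over directly. Without a closer precedent, compound 3 is expected to sit near compound 2, with a step of a 1.3-fold lower number from compound 2 to compound 3 (0.12 log units; within the scatter) in this assay. Compound 3 is estimated at 150 ug/mL, with a plausible range from 40 ug/mL to 600 ug/mL.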

Compound 3, solubility: > 1000 ug/mL
Compound 3: no number, only a limit; the forecaster's own chance of this, stated with the estimate: 10%; middle value at least 6.6-fold (0.82 log units) from the limit.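

At this place, on a saturated chain carbon bound to a carbonyl carbon, 2-methoxyethoxy in place of amino gives an at least 5.0-fold higher number from compound 2 to compound 3 (0.69 log units; beyond the scatter) in this assay. Among the compounds shown here, until this result, compound 1, with its carboxymethyl group, was the only compound reported as a limit rather than a plain number. Compound 3 now sits at that same limit with a chain that has no carboxymethyl group, so carboxymethyl is not the only group at this place that goes with such a reading, and the true size of the step from amino and any comparison of compound 1 with compound 3 cannot be read, because both values are limits: the limit of > 1000 ug/mL in this assay, at which 2 of the 3 values shown sit.

The compounds shown leave open whether the higher number follows the loss of amino or the arrival of the ether chain, and a methoxy group or a hydroxyl group at this place would help to separate the two. They also leave open whether a longer ether chain or a tertiary amine at the same carbon would stay at the limit or fall back towards compound 2.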